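Dichlorophenyl variants on a shared dihydrofolate reductase inhibitor core

The source may report more compounds than this note shows. Statements on the series, on what has been measured and on what is new or still open speak of the compounds shown alone.

The series rests on a common core, seen in compound 1 `NC1=NC2(CCOCC2)N(OCCCOc2cccc(Cl)c2Cl)C(N)=N1` and compound 2 `Cc1cc(C)cc(OCCCON2C(N)=NC(N)=NC23CCOCC3)c1`. In an assay on isolated protein for inhibition of Dihydrofolate reductase (Homo sapiens), read by spectrophotometry, using NADPH, with stated times of 5 s and 6 min, tested at 5 uM (on this read-out higher numbers stand for a stronger effect at the one concentration tested and lower numbers for a weaker effect), compound 1 gives 81.7%, and compound 2 gives 84.3%. Compound 2 holds the higher of the two numbers, yet its nearest neighbour, compound 1, lies within the scatter of it, as the step of a number 2.6 percentage points higher from compound 1 to compound 2 (within the scatter) shows.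

The next compound, compound 3 `NC1=NC2(CCOCC2)N(OCCCOc2ccc(Cl)cc2Cl)C(N)=N1`, is yet to be measured in this assay. Its change from compound 2 is 2,4-dichlorophenyl in place of 3,5-dimethylphenyl on an oxygen on a saturated carbon, which places a dichlorophenyl on the same oxygen on a saturated carbon where compound 1 already carried one. Going by the values given here, the only step that bears on this change is a number 2.6 percentage points higher from compound 1 to compound 2 (within the scatter); that exchange of an aryl group at this position moved the read-out by no more than the scatter. On that basis no step beyond the scatter is expected for compound 3, and its expected step is a number 2.3 percentage points lower from compound 2 to compound 3 (within the scatter). Compound 3 is therefore estimated to give 82%, with a range from 70% to 92%.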

Compound 3, a percentage reported as inhibition, at one concentration (the size of the read-out at that concentration, not a potency): > 90%
Compound 3 was reported as a limit; the forecaster's own chance of this, stated with the estimate: 0%; middle value at least 8 percentage points from the limit.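

In this assay compound 3 gives > 90%, which is a limit of the assay and not a number. Both steps to it, a number at least 5.7 percentage points higher from compound 2 to compound 3 (that floor lies within the scatter) and a number at least 8.3 percentage points higher from compound 1 to compound 3 (that floor lies within the scatter), are therefore floors, so the data show that 2,4-dichlorophenyl on an oxygen on a saturated carbon keeps the read-out at a high level but do not establish a true gain over either 3,5-dimethylphenyl or 2,3-dichlorophenyl. The second step also adds something the earlier pair could not show, a comparison of two dichlorophenyl groups at this place, and compound 3 is the only one of the three compounds to reach the limit: the limit of > 90% in this assay, at which 1 of the 3 values shown sits.

Going by these compounds, the true size of both steps remains open, since a limit at one tested concentration gives no potency and cannot separate compound 3 from anything else that reaches it. The three compounds shown all carry a substituted phenyl at this place, which leaves open how the read-out would respond to an amine or a carboxylic acid there in place of the aryl group.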